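The compounds below may be only part of what the source reports. "The series", "measured", "known", "first", "only" and "open" are said of these compounds alone.

Measured in a functional assay on HepG2 cells (Homo sapiens) for antiproliferative activity, read by MTT assay, with a stated time of 48 h; a higher number here means a weaker inhibitor, a lower number a stronger inhibitor:
- Compound 1 `CCN(CC)CCNC(=O)c1ccc(C(CC)(CC)c2ccc(OCCC(O)(CC)CC)c(C)c2)n1CC`: 230 nM
- Compound 2 `CCn1c(C(=O)NCCN)ccc1C(CC)(CC)c1ccc(OCCC(O)(CC)CC)c(C)c1`: 1590 nM

Compound 1 has the lower number of the two, which makes it the stronger inhibitor of this pair. Compound 3 `C=CCN(C)C(=O)c1ccc(C(CC)(CC)c2ccc(OCCC(O)(CC)CC)c(C)c2)n1CC` has not been measured yet. It keeps the core of compound 1 but carries a different group on the carbonyl carbon: allyl(methyl)amino in place of (2-(diethylamino)ethyl)amino on a carbonyl carbon. Allyl(methyl)amino stands in place of (2-(diethylamino)ethyl)amino.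

Among the measured compounds shown here, only one measured step bears on this change: a 6.9-fold higher number from compound 1 to compound 2 (0.84 log units; beyond the scatter). There, the diethylamino group gave way to amino while the chain stayed. Compound 3 loses that diethylamino group and the chain as well, so this step is only a rough guide. On that basis, a move to a higher number of similar size is expected, with no firm sign of how much further it may go. The expected change is a 6.5-fold higher number from compound 1 to compound 3 (0.81 log units; beyond the scatter). The estimate for compound 3 is 1500 nM, with an expected range from 400 nM to 6000 nM.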

Compound 3, half-maximal inhibitory concentration: > 50000 nM
Compound 3 gave a limit, no number; the forecaster's own chance of this, stated with the estimate: 10%; middle value at least 33-fold (1.52 log units) away from the limit.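

Compound 3 gives no number in this assay, only a limit: the limit of > 50000 nM in this assay, at which 1 of the 3 values shown sits. Placing allyl(methyl)amino on the carbonyl carbon instead of (2-(diethylamino)ethyl)amino gives an at least 210-fold higher number from compound 1 to compound 3 (2.33 log units; beyond the scatter), and placing it there instead of (2-aminoethyl)amino gives an at least 31-fold higher number from compound 2 to compound 3 (1.49 log units; beyond the scatter). Both steps go well beyond the change at the end of the chain alone, which gave a 6.9-fold higher number from compound 1 to compound 2 (0.84 log units; beyond the scatter), so among these three compounds, replacing the whole group costs far more than trimming the diethylamino end to amino.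

The swap removes the chain, its end nitrogen and the amide hydrogen all at once, and the three compounds cannot say which of these matters. A plain ethylamino group on the carbonyl carbon, or a longer chain ending in diethylamino, would help separate them.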